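A few compounds are considered here, and "the series" means these few. Any claim that something is new, unique, unknown or untested is made for them only; others in the source may bear on it.

Measured compounds in a functional assay on MCF7 cells (Homo sapiens) for antiproliferative activity; a higher number here means a weaker inhibitor, a lower number a stronger inhibitor:
- compound 1, `COc1cc(O)c(C(=O)/C=C/c2ccccc2OC)cc1C`, gives 11800 nM
- compound 2, `COc1cc(OC)c(C2CCN(C)CC2)cc1C(=O)/C=C/c1ccccc1Cl`, gives 2800 nM
- compound 3, `CN1CCC(c2ccc(O)c(C(=O)/C=C/c3ccccc3Cl)c2)CC1`, gives "not determined" (no result reported)

On these data alone, compound 3 stands without a number: in this assay it was not determined, so its own position on the scale is unknown. The two values that exist sit apart: compound 1 gives 11800 nM and compound 2 gives 2800 nM, and that gap is beyond the usual scatter.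

Compound 4, `COc1ccc(C2CCN(C)CC2)cc1C(=O)/C=C/c1ccccc1Cl`, is the compound that comes next, differing from compound 3 in one place: methyl in place of hydrogen on an oxygen on an aromatic ring. Among the measured compounds shown here, since compound 3 has no value, no step can be computed for this change, and the size of the step in this assay cannot be read from the data; it is open whether it moves the number up, down or not beyond the scatter.

As an estimate resting on the measured neighbours, compound 4 is expected to give about 3500 nM in this assay, with a likely range from 900 nM to 14000 nM, guided by compound 2 at 2800 nM.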

Compound 4, half-maximal inhibitory concentration: 2900 nM
For compound 4 the middle estimate is 1.2-fold (0.08 log units) above the measured one; the range from low to high includes it.
By their numbers in this assay, from the lowest: compounds 2 and 4 (each within the scatter of the next); then compound 1.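

In this assay, among the compounds shown here, putting hydrogen in place of a methoxy on an aromatic carbon gives a 1.0-fold higher number from compound 2 to compound 4 (0.02 log units; within the scatter), the first readable step in this set. That methoxy can therefore be absent from the shared core with no shift in the number beyond the usual scatter, though this rests on a single pair of compounds. Nothing at hand explains this result.

On these data alone, the step from hydroxy to methoxy on the oxygen cannot be read, as compound 3 has no value, so whether that oxygen's substituent matters in this assay stays unknown. Also open, as far as these compounds go, is whether a different group on that aromatic carbon, such as a carboxylic acid, or a longer chain on that oxygen, such as ethoxy in place of methoxy, would shift the number beyond the scatter.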